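Chloro for hydrogen on the core: acetylated pair

The source may hold more compounds than are shown below. What is called first, only, known or untested is meant among the compounds shown, and "the series" means these compounds.

Measured so far:
- Compound 1, `OC[C@@H](O)[C@H]1O[C@@H](n2cnc3c(Cl)ncnc32)[C@H](O)[C@@H]1O`; in a functional assay on HeLa cells (Homo sapiens), read by colorimetric assay, with a stated time of 48 h (on this read-out higher numbers stand for weaker inhibition and lower numbers for stronger inhibition), compound 1 reads > 100000 nM, which is a limit of the assay and not a number.
- Compound 2, `OC[C@@H](O)[C@H]1O[C@@H](n2cnc3c(Cl)nc(Cl)nc32)[C@H](O)[C@@H]1O`; in this assay compound 2 gives 47100 nM.
- Compound 3, `CC(=O)OC[C@@H](OC(C)=O)[C@H]1O[C@@H](n2cnc3c(Cl)ncnc32)[C@H](OC(C)=O)[C@@H]1OC(C)=O`; in this assay compound 3 reads > 100000 nM, again a limit and not a number.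

Compound 1 sits at the limit of > 100000 nM in this assay, at which 2 of the 3 values shown sit. Within the data shown here, the one counted step is chloro in place of hydrogen on an aromatic carbon and it gives an at least 2.1-fold lower number from compound 1 to compound 2 (0.32 log units; beyond the scatter); since the starting point is a limit, only the lower bound of that step is known. How the core of compound 3 differs from the core of compound 1 is not broken down here; both carry the same heterocycle, compound 3 with four acetate groups on the sugar.

Compound 4, `CC(=O)OC[C@@H](OC(C)=O)[C@H]1O[C@@H](n2cnc3c(Cl)nc(Cl)nc32)[C@H](OC(C)=O)[C@@H]1OC(C)=O`, has not been measured. It stands to compound 3 as compound 2 stands to compound 1: chloro in place of hydrogen on an aromatic carbon, the same change at the same place. Among the measured compounds shown here, because compound 3 reads only a limit, the size of the step to compound 4 cannot be checked against anything from the acetylated side; the only guide is the step from compound 1 to compound 2. The expected step is an at least 1.6-fold lower number from compound 3 to compound 4 (0.22 log units; that floor lies within the scatter), resting on that single precedent. Compound 4 is therefore estimated at 60000 nM, with a range from 20000 nM to 200000 nM, and a real chance that the assay again returns only a limit.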

Compound 4, half-maximal inhibitory concentration: 24200 nM
Compound 4: middle estimate off by 2.5-fold (0.39 log units), on the high side, and the stated range covers the measured number.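

The change of hydrogen to chloro on an aromatic carbon, between two ring nitrogen atoms, also lowers the number on the acetylated sugar: in this assay it gives an at least 4.1-fold lower number from compound 3 to compound 4 (0.61 log units; beyond the scatter). Compound 1 and compound 3 both stand at a limit and not at a number, so only lower bounds of the two steps are known: the limit of > 100000 nM in this assay, at which 2 of the 4 values shown sit. The two pairs show the same direction of change, and a step beyond the scatter, with the free hydroxyl groups and with the four acetate groups, but they do not show whether the size of the step depends on the core: the same change on two cores in this assay, an at least 2.1-fold lower number (0.32 log units; beyond the scatter) from compound 1 to compound 2 and an at least 4.1-fold lower number (0.61 log units; beyond the scatter) from compound 3 to compound 4; the limit leaves it open whether they differ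

From the compounds shown here alone, it remains open whether the gain belongs to chloro in particular or would also appear with another group at the same ring carbon, such as an amine, a methoxy group or a bromo group. Also open, going by these compounds, is how the series responds when the four acetate groups give way to esters with a longer chain, such as butyrate, or when only some of the acetate groups are present.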